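The source may report more compounds than this note shows. Statements on the series, on what has been measured and on what is new or still open speak of the compounds shown alone.

Measured in a functional assay on MIA PaCa-2 cells (Homo sapiens) for antiproliferative activity; on this read-out lower numbers stand for an effect already at smaller amounts and higher numbers for an effect only at larger amounts of compound:
- compound 1 `C#CCNC(=O)c1cccc2c1cc(C)n2-c1nc2c(c(NCc3ccccc3)n1)CCCC2` – 470 nM
- compound 2 `CC#CC(=O)Nc1cccc2c1cc(C)n2-c1nc2c(c(NCc3ccccc3)n1)CCCC2` – 436 nM

Compound 2, at 436 nM, lies within the scatter of compound 1, so neither can be placed ahead of the other. Compound 3 `CCC(=O)Nc1cccc2c1cc(C)n2-c1nc2c(c(NCc3ccccc3)n1)CCCC2` carries ethyl in place of prop-1-yn-1-yl on a carbonyl carbon, which turns (prop-1-yn-1-yl)carbonyl into propanoyl. Among the compounds with values here, only one measured step is available, a 1.1-fold lower number from compound 1 to compound 2 (0.03 log units; within the scatter), and it stays within the scatter. Both of its compounds keep a triple bond outside aromatic rings, so no measurement shows what losing that bond does. A small step is therefore expected in this assay, perhaps towards a somewhat higher number, with the direction uncertain. The expected step is a 1.4-fold higher number from compound 2 to compound 3 (0.14 log units; within the scatter). For compound 3 the estimated value is 600 nM, with an expected range of 220 nM to 1600 nM.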

Compound 3, half-maximal effective concentration: 1010 nM
Beside the measured number, compound 3's estimate is 1.7-fold (0.23 log units) below it; the range from low to high includes it.
By their numbers in this assay, from the lowest: compounds 2 and 1 (each within the scatter of the next); then compound 3.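

In this assay, within the data shown here, ethyl in place of prop-1-yn-1-yl on a carbonyl carbon gives a 2.3-fold higher number from compound 2 to compound 3 (0.36 log units; beyond the scatter), the first step beyond the scatter and the first reading on a compound without a triple bond outside aromatic rings. Propanoylamino in place of propargylcarbamoyl on an aromatic carbon gives a 2.1-fold higher number from compound 1 to compound 3 (0.33 log units; beyond the scatter), so both compounds with a triple bond give lower numbers than compound 3, though the steps remain modest. Nothing at hand explains this difference.

This change removes the triple bond and shortens the chain together, leaving their separate contributions open; a propyl group on the carbonyl carbon would keep the carbon count of prop-1-yn-1-yl without the triple bond. Going by these compounds, how an amine or a carboxylic acid at the end of this chain would read also remains open.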